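Extending Methyl to Ethyl on the Shared Core

The compounds below may be only part of what the source reports. "The series", "measured", "known", "first", "only" and "open" are said of these compounds alone.

- In a functional assay on the whole organism (Pleural cavity) for inhibition, with Rattus norvegicus as the target, at a dose of 25 mg/kg (on this read-out lower numbers stand for less inhibition and higher numbers for more inhibition at the one dose given (going by the name of the read-out)), compound 1 `CC1(Sc2ccccc2)C(=O)N(c2ccccc2)c2ncccc21` gives 0%.
- In this assay compound 2 `CC1(Cc2ccccc2)C(=O)N(c2ccccc2)c2ncccc21` gives 0%.
- In this assay compound 3 `CCC1(C)C(=O)N(c2ccccc2)c2ncccc21` gives 12%.

Compound 3 stands highest of the three numbers, the other two each lying lower by a step beyond the scatter: a number 12 percentage points higher from compound 1 to compound 3 (beyond the scatter) and a number 12 percentage points higher from compound 2 to compound 3 (beyond the scatter). Compound 4 `CCC1(CC)C(=O)N(c2ccccc2)c2ncccc21` differs from compound 3 by methyl in place of hydrogen on a saturated chain carbon bound to a saturated ring carbon. The step bearing most on this change is a number 12 percentage points higher from compound 2 to compound 3 (beyond the scatter), where phenyl gave way to methyl on the same kind of chain carbon and the number rose modestly. The change to compound 4 adds only one carbon, so no step beyond the scatter is expected, the expected step being no change at the digits printed from compound 3 to compound 4 (within the scatter). Compound 4 is therefore estimated at 12%, within 0% to 28%.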

Compound 4, a percentage reported as inhibition, in the whole organism at one dose (the size of the read-out at that dose, not a potency): 0%
The estimate for compound 4 lay 12 percentage points above the measured number; the measured number falls inside the stated range.
By their numbers in this assay, from the lowest: compounds 1, 2 and 4 (each within the scatter of the next); then compound 3.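

At this place a single added carbon is enough to matter: methyl to ethyl gives a number 12 percentage points lower from compound 3 to compound 4 (beyond the scatter) in this assay and leaves compound 3 as the only one of the four standing apart from the rest. A small alkyl group here therefore does not guarantee a number above the others, and the result turns on the exact group. Nothing measured here explains this drop.

Going by these compounds, whether a propyl chain, an amine or a carboxylic acid in place of the ethyl of compound 3 would keep or lose the inhibition remains open.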